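This account rests on a few compounds, and the source may have more. Where it says the series, first, only, none or still open, it means among the compounds named here.

Of the compounds shown here, three sharing one core have been measured in a functional assay (trachea) with Cavia porcellus as the target; a higher number here means a weaker inhibitor, a lower number a stronger inhibitor. Compound 1 `Cn1nc(-c2cccnc2)c2ccccc2c1=O`, with methyl on the aromatic nitrogen, gives 11500 nM. Compound 2 `CC(C)n1nc(-c2cccnc2)c2ccccc2c1=O`, with isopropyl there, gives 3090 nM, and compound 3 `O=c1c2ccccc2c(-c2cccnc2)nn1C1CCCC1`, with cyclopentyl, gives 2750 nM. Replacing methyl brought modest gains, a 3.7-fold lower number from compound 1 to compound 2 (0.57 log units; beyond the scatter) with isopropyl and a 4.2-fold lower number from compound 1 to compound 3 (0.62 log units; beyond the scatter) with cyclopentyl. The exchange between the two larger groups made no measurable difference, a 1.1-fold lower number from compound 2 to compound 3 (0.05 log units; within the scatter). Compound 3 therefore stands level with compound 2, and both lie clearly under compound 1.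

Compound 4 `O=c1c2ccccc2c(-c2cccnc2)nn1Cc1ccccc1` carries benzyl in place of cyclopentyl on an aromatic nitrogen. Among the measured compounds shown here, none of the measured compounds has an aromatic ring on this nitrogen, so the data offer no direct precedent and the range must stay wide. For the measured compounds named here, the nearest guide is the flat exchange between isopropyl and cyclopentyl, while the modest steps away from methyl show how far this position has moved the number so far. In this assay, no change beyond the scatter is therefore expected, in either direction. The estimated step is a 1.1-fold lower number from compound 3 to compound 4 (0.04 log units; within the scatter). Compound 4 is expected at about 2500 nM, with an estimated range from 800 nM to 7500 nM.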

Compound 4, half-maximal inhibitory concentration: 2450 nM
For compound 4 the middle estimate is 1.0-fold (0.01 log units) above the measured one; measured number inside the range.
By their numbers in this assay, from the lowest: compounds 4, 3 and 2 (each within the scatter of the next); then compound 1.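

Benzyl brings an aromatic ring onto this nitrogen for the first time, and in this assay it sits level with the saturated groups, both against cyclopentyl (a 1.1-fold lower number from compound 3 to compound 4 (0.05 log units; within the scatter)) and against isopropyl (a 1.3-fold lower number from compound 2 to compound 4 (0.10 log units; within the scatter)). The gain over methyl therefore survives the change from a saturated to an aromatic group (a 4.7-fold lower number from compound 1 to compound 4 (0.67 log units; beyond the scatter)), and among these four compounds only compound 1, with methyl, stands apart, while compounds 2, 3 and 4 cannot be told apart. Nothing at hand accounts for why these three different groups give matching numbers.

The compounds shown carry only carbon in the group on this nitrogen, so it remains open whether an amine, a carboxylic acid or a longer chain ending in a hydroxyl group would leave the number where it stands or move it. As far as these compounds go, it is equally open whether a substituent such as chlorine or methoxy on the benzyl ring would separate anything from compound 4, or whether the pyridin-3-yl group matters at all, since it is the same throughout.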